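The source may report more compounds than this note shows. Statements on the series, on what has been measured and on what is new or still open speak of the compounds shown alone.

In an ADME assay on MT2 cells (Homo sapiens) for cytotoxicity, read by XTT assay, with a stated time of 4 days (on this read-out higher numbers stand for lower toxicity in this test and lower numbers for higher toxicity in this test), compound 3 (`CC(=O)N1CCCCC1C(NC(=O)C(=O)Nc1ccc(Cl)cc1)c1nc(C)c(CCO)s1`) gives > 84000 nM, which is a limit and not a number. Compound 1 (`Cc1nc(C(NC(=O)C(=O)Nc2ccc(Cl)cc2)C2CCNCC2)sc1CCO`) gives > 78500 nM, also a limit. Within the data shown here, with compound 2 (`Cc1ccc(NC(=O)C(=O)NC(c2nc(C)c(CCO)s2)C2CCCCN2)c(F)c1`) still to come, the values so far offer no number against which compound 3 can be placed.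

Compound 4 (`Cc1nc(C(NC(=O)C(=O)Nc2ccc(Cl)cc2)C2CCCCN2)sc1CCO`) differs from compound 3 by one change, hydrogen in place of acetyl on an amine nitrogen in a ring. Among the measured compounds shown here, the only measured step that touches this change is a step that the two limits leave unreadable from compound 1 to compound 3, and it has no readable size.

Some guidance comes from compound 2, which has piperidin-2-yl without the acetyl and gives > 78800 nM, again a limit. No step beyond the usual scatter is therefore expected in this assay, and the result will probably be a limit too. The expected change is an at least 1.0-fold lower number from compound 3 to compound 4 (0.02 log units; that floor lies within the scatter). Compound 4 is estimated at 80000 nM, with an expected range from 35000 nM to 150000 nM.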

Compound 4, half-maximal cytotoxic concentration: > 62000 nM
Compound 4: only a limit was reported (the forecaster's own chance of this, stated with the estimate: 85%); the middle value is on the limit's open side.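

In this assay compound 4 is reported only as a limit, as are compound 1, compound 2 and compound 3, and no step among these four can be read. The compounds shown leave open the actual half-maximal cytotoxic concentration of each, and whether hydrogen in place of acetyl changes it at all.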